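The source may report more compounds than this note shows. Statements on the series, on what has been measured and on what is new or still open speak of the compounds shown alone.

In a functional assay on A549 cells (Homo sapiens) for inhibition, read by MTT assay, with a stated time of 72 h (a lower number here means a stronger inhibitor, a higher number a weaker inhibitor), compound 1 `CN(C(=O)NC(=O)c1ccc(Cl)cc1Cl)c1nc(C(F)(F)F)c(C(=O)N/N=C/c2ccc(C(F)(F)F)cc2)s1` gives 9.4 ug/mL, compound 3 `CN(C(=O)NC(=O)c1ccccc1F)c1nc(C(F)(F)F)c(C(=O)N/N=C/c2ccccc2C(F)(F)F)s1` gives 6.32 ug/mL, and compound 2 `Cc1nc(N(C)C(=O)NC(=O)c2ccc(Cl)cc2Cl)sc1C(=O)N/N=C/c1ccc(C(F)(F)F)cc1` gives 30.2 ug/mL, the highest of the three numbers. For the measured compounds named here, the single measured step, a 3.2-fold higher number from compound 1 to compound 2 (0.51 log units; beyond the scatter), sits on the shared core rather than at the carbonyl carbon. Compound 4 `Cc1nc(N(C)C(=O)NC(=O)c2c(F)cccc2F)sc1C(=O)N/N=C/c1ccc(C(F)(F)F)cc1` differs from compound 2 by 2,6-difluorophenyl in place of 2,4-dichlorophenyl on a carbonyl carbon. Going by the values given here, no measured step tracks this change directly; compound 1 and compound 3 differ at that carbonyl carbon and in a second place, and their two values lie within the scatter of each other. For compound 4 the expected step is therefore small, estimated as a 1.4-fold lower number from compound 2 to compound 4 (0.14 log units; within the scatter). Compound 4 is expected to give about 22 ug/mL in this assay, with a range from 9 ug/mL to 55 ug/mL.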

Compound 4, half-maximal inhibitory concentration: 60.5 ug/mL
Compound 4: middle estimate off by 2.8-fold (0.44 log units), on the low side; the measured number lies above the stated range.
By their numbers in this assay, from the lowest: compounds 3 and 1 (each within the scatter of the next); then compounds 2 and 4 (each within the scatter of the next).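

Replacing 2,4-dichlorophenyl with 2,6-difluorophenyl on the carbonyl carbon now has a direct reading, a 2.0-fold higher number from compound 2 to compound 4 (0.30 log units; within the scatter) in this assay on the methyl-bearing core. On that core, this change therefore does not separate the two compounds beyond the usual scatter. No available evidence bears on this result. From the compounds shown here alone, whether the change reads the same on the trifluoromethyl-bearing core of compound 1 remains open. So does the effect of a hexyl chain or an aminophenyl group on that carbonyl carbon.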